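The source may hold more compounds than are shown below. What is called first, only, known or untested is meant among the compounds shown, and "the series" means these compounds.

Measured compounds:

compound 1, `CNC(=O)CCCCCCCn1nc(-c2cnc3[nH]ccc3c2)c2c(N)ncnc21` — 5630 nM
compound 2, `Nc1ncnc2c1c(-c1cnc3[nH]ccc3c1)nn2CCCCCCC(=O)NO` — 10300 nM
compound 3, `CNC(=O)CCCCCCCn1nc(-c2ccc3oc(N)nc3c2)c2c(N)ncnc21` — 3640 nM

All three were tested in a functional assay on HepG2 cells (Homo sapiens) for inhibition, read by MTT assay, with a stated time of 72 h; on this read-out higher numbers stand for weaker inhibition and lower numbers for stronger inhibition. Compound 4, `Nc1nc2cc(-c3nn(CCCCCCC(=O)NO)c4ncnc(N)c34)ccc2o1`, has not yet been measured there.

Compound 1 and compound 2 share a core and differ in one place: hydroxycarbamoyl in place of (methylcarbamoyl)methyl on a saturated chain carbon, six bonds along the chain from an aromatic nitrogen. This change gave a 1.8-fold higher number from compound 1 to compound 2 (0.26 log units; within the scatter). Compound 1 and compound 3 carry the same chain and differ only in the core: a group of 10 heavy atoms (7 carbon, 2 nitrogen, 1 oxygen; one five-membered aromatic ring with 2 hetero atoms, one six-membered aromatic ring of carbon only) in place of a group of 9 heavy atoms (7 carbon, 2 nitrogen; one five-membered aromatic ring with 1 hetero atom, one six-membered aromatic ring with 1 hetero atom), on an aromatic carbon. That change gave a 1.5-fold lower number from compound 1 to compound 3 (0.19 log units; within the scatter). Within the data shown here, of the three numbers, compound 3 has the lowest, with compound 1 close to it, while the gap between compound 3 and compound 2 is wider than the scatter of this assay; no single step between compound 2 and compound 3 is given, so only their two values speak.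

Compound 4 is related to compound 3 by the same change that relates compound 1 to compound 2: hydroxycarbamoyl in place of (methylcarbamoyl)methyl on a saturated chain carbon, six bonds along the chain from an aromatic nitrogen. The place is described in the same words in both cases, so this is the same change on the core of compound 3 rather than on the core of compound 1.

Among the measured compounds shown here, the only guide is the step seen once already, and compound 4 is expected to move from compound 3 by a 1.8-fold higher number from compound 3 to compound 4 (0.25 log units; within the scatter), a step estimated to be close in size to a 1.8-fold higher number from compound 1 to compound 2 (0.26 log units; within the scatter). Since that earlier step lay within the scatter, the expected number for compound 4 rests loosely on the value of compound 3, 3640 nM, with a wide spread.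

Compound 4 is therefore estimated at 6500 nM in this assay, with a likely range from 3000 nM to 15000 nM.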

Compound 4, half-maximal inhibitory concentration: 1610 nM
Beside the measured number, compound 4's estimate is 4.0-fold (0.61 log units) above it; the whole stated range lies above it.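

In this assay, putting hydroxycarbamoyl in place of (methylcarbamoyl)methyl on the core of compound 3 gave a 2.3-fold lower number from compound 3 to compound 4 (0.35 log units; beyond the scatter), so the change did not carry over from the core of compound 1 with the same size: the same change on two cores in this assay, a 1.8-fold higher number (0.26 log units; within the scatter) from compound 1 to compound 2 and a 2.3-fold lower number (0.35 log units; beyond the scatter) from compound 3 to compound 4, 4.1-fold (0.62 log units) apart, beyond the scatter of two such steps Seen from the other side of the same four compounds, the exchange of the aromatic group gave a 6.4-fold lower number from compound 2 to compound 4 (0.81 log units; beyond the scatter) with hydroxycarbamoyl in the chain, and this step too differs from its counterpart with (methylcarbamoyl)methyl: the same change on two cores in this assay, a 1.5-fold lower number (0.19 log units; within the scatter) from compound 1 to compound 3 and a 6.4-fold lower number (0.81 log units; beyond the scatter) from compound 2 to compound 4, 4.1-fold (0.62 log units) apart, beyond the scatter of two such steps These compounds show that the effect of this change depends on the core it is made on, so a step read on one core is a poor guide to the next, but both comparisons rest on the same four compounds, the step on the core of compound 1 lies within the scatter, and nothing here says why the two cores part.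

As far as these compounds go, it remains open whether a carboxylic acid or a primary amide in place of hydroxycarbamoyl would show the same dependence on the core, and whether it would persist with a shorter or longer chain. Further aromatic groups on the shared core would be needed to tell whether compound 4 is a single case or part of a wider trend.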